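Series notes: compound 4 at the varied ring position

A few compounds are considered here, and "the series" means these few. Any claim that something is new, unique, unknown or untested is made for them only; others in the source may bear on it.

The three measured compounds share one core and differ only in the group on an oxygen on an unsaturated carbon. In a functional assay on A549 cells (Homo sapiens) for antiproliferative activity, read by MTT assay, with a stated time of 72 h (a higher number here means a weaker inhibitor, a lower number a stronger inhibitor), compound 1 `CC(C)OC1=C(C(=O)c2ccccc2)C(c2ccc(Br)cc2)N(CCCn2ccnc2)C1=O` gives 8720 nM. Compound 2 `CCCCCOC1=C(C(=O)c2ccccc2)C(c2ccc(Br)cc2)N(CCCn2ccnc2)C1=O` gives 7290 nM in this assay, and the step of a 1.2-fold lower number from compound 1 to compound 2 (0.08 log units; within the scatter) is within the scatter. Compound 3 `O=C(C1=C(OC2CCCCC2)C(=O)N(CCCn2ccnc2)C1c1ccc(Br)cc1)c1ccccc1` gives 31200 nM; it stands highest of the three numbers, nearest to compound 1 and furthest from compound 2, both gaps beyond the scatter: a 3.6-fold higher number from compound 1 to compound 3 (0.55 log units; beyond the scatter) and a 4.3-fold higher number from compound 2 to compound 3 (0.63 log units; beyond the scatter).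

Compound 4 `O=C(C1=C(Nc2ccc(I)cc2)C(=O)N(CCCn2ccnc2)C1c1ccc(Br)cc1)c1ccccc1` awaits measurement. The change is (4-iodophenyl)amino in place of cyclohexyloxy on a double-bonded ring carbon. Among the measured compounds shown here, the steps that bear on it are those ending in compound 3, both modest in size and both changes of the group on the same oxygen. For the measured compounds named here, no measured step swaps the oxygen link for a nitrogen link or brings an aromatic ring to this position, so the direction is not settled by the data. Because a 3.6-fold higher number from compound 1 to compound 3 (0.55 log units; beyond the scatter) and a 4.3-fold higher number from compound 2 to compound 3 (0.63 log units; beyond the scatter) both raised the number on arriving at cyclohexyl, leaving cyclohexyl is expected to lower it modestly, with wide uncertainty. Compound 4 is therefore estimated at 10000 nM, range 3000 nM to 40000 nM, a step of a 3.1-fold lower number from compound 3 to compound 4 (0.49 log units; beyond the scatter).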

Compound 4, half-maximal inhibitory concentration: 24500 nM
Estimate against measurement, compound 4: 2.5-fold (0.39 log units) below; measured number inside the range.
By their numbers in this assay, from the lowest: compounds 2 and 1 (each within the scatter of the next); then compounds 4 and 3 (each within the scatter of the next).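

The new group changes the linking atom and brings an aromatic ring to this position, and in this assay the change from cyclohexyloxy to (4-iodophenyl)amino cannot be told from the scatter: a 1.3-fold lower number from compound 3 to compound 4 (0.10 log units; within the scatter). Against the open-chain groups, the same (4-iodophenyl)amino group gives a 2.8-fold higher number from compound 1 to compound 4 (0.45 log units; beyond the scatter) and a 3.4-fold higher number from compound 2 to compound 4 (0.53 log units; beyond the scatter), so compound 4 lies with compound 3 and apart from compound 1 and compound 2. Across these four compounds, the two groups that carry a six-membered ring, one aromatic and one not, stand together on the higher side of the open-chain isopropoxy and pentyloxy groups, and no compound shown goes against this, although the entering group also adds a hydrogen-bond donor.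

No measured evidence bears on the reason for this result. On these data alone, the oxygen-to-nitrogen exchange, the aromatic ring and the iodine all arrive in one step, so their separate contributions remain open, and an unsubstituted phenylamino group, a phenoxy group or an open-chain pentylamino group would be needed to separate them.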